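Swapping the chain end: carbamoyl to aminooxyethyl

This account rests on a few compounds, and the source may have more. Where it says the series, first, only, none or still open, it means among the compounds named here.

Compound 1 `Cc1nc2c(N)ncnc2n1[C@@H]1O[C@H](CN(C)CCC(N)=O)[C@@H](O)[C@H]1O` gives 400 nM in an assay on isolated protein for inhibition of S-adenosylmethionine decarboxylase proenzyme (Homo sapiens); a lower number here means a stronger inhibitor, a higher number a weaker inhibitor. Compound 2 `CN(CCC(N)=O)C[C@H]1O[C@@H](n2cnc3c(N)ncnc32)[C@H](O)[C@@H]1O` gives 7000 nM in this assay, and compound 3 `CCc1nc2c(N)ncnc2n1[C@@H]1O[C@H](CN(C)CCC(N)=O)[C@@H](O)[C@H]1O` gives 4000 nM. Compound 3 stands second highest of the three numbers: a 10-fold higher number from compound 1 to compound 3 (1.00 log units; beyond the scatter), while a 1.8-fold lower number from compound 2 to compound 3 (0.24 log units; within the scatter). Compound 4 `CCc1nc2c(N)ncnc2n1[C@@H]1O[C@H](CN(C)CCCCON)[C@@H](O)[C@H]1O` differs from compound 3 by 2-(aminooxy)ethyl in place of carbamoyl on a saturated chain carbon, two bonds along the chain from an amine nitrogen. Among the measured compounds shown here, every measured step, an 18-fold higher number from compound 1 to compound 2 (1.24 log units; beyond the scatter) included, alters the group on the aromatic carbon of the shared core, and none touches the chain end, so no measured step bears directly on this change. The outcome is therefore open, and a wide range is appropriate. Compound 4 is expected to give 4000 nM, within 800 nM to 20000 nM. The step this estimate implies is no change at the digits printed from compound 3 to compound 4 (within the scatter).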

Compound 4, half-maximal inhibitory concentration: 15 nM
The estimate for compound 4 lay 270-fold (2.43 log units) above the measured number; measured number outside the range, below it.
By their numbers in this assay, from the lowest: compound 4; then compound 1; then compounds 3 and 2 (each within the scatter of the next).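

Among the compounds shown here, the chain end, which no earlier compound varied, turns out to matter greatly: 2-(aminooxy)ethyl in place of carbamoyl gives a 270-fold lower number from compound 3 to compound 4 (2.43 log units; beyond the scatter) and exceeds every step seen at the aromatic carbon of the shared core. Nothing measured here explains this gain. The change swaps the end group and adds a heavy atom at once, so the compounds shown do not separate these two effects. From the compounds shown here alone, whether an amine or a carboxylic acid at the chain end would do the same, and whether methyl in place of ethyl on the aromatic carbon would add to the gain, remains open.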